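The compounds below may be only part of what the source reports. "The series", "measured", "known", "first", "only" and "open" are said of these compounds alone.

Measured compounds:
- Compound 1, `Cc1ccc(C(=O)NNC(=O)c2ccc(NS(=O)(=O)c3cnc(O)nc3O)cc2)cc1`: 15900 nM
- Compound 2, `O=C(NNC(=O)c1ccccc1Cl)c1ccc(NS(=O)(=O)c2cnc(O)nc2O)cc1`: 1900 nM
- Compound 3, `Cc1ccc(C(=O)NNC(=O)c2ccccc2NS(=O)(=O)c2cnc(O)nc2O)cc1`: > 20000 nM

All three were tested in a functional assay on A549 cells (Homo sapiens) for antiproliferative activity, read by MTT assay, with a stated time of 24 h; a higher number here means a weaker inhibitor, a lower number a stronger inhibitor. Compound 1 gives 15900 nM in this assay. Compound 2 gives 1900 nM. Compound 3 gives > 20000 nM, which is a limit of the assay and not a number.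

Compound 1 and compound 2 differ by one change, (2-chlorophenyl in place of 4-methylphenyl on a carbonyl carbon), and this gave an 8.4-fold lower number from compound 1 to compound 2 (0.92 log units; beyond the scatter). Compound 3 shares its atoms with compound 1 but joins them differently; how the two cores differ is not broken down here. Compound 4, `O=C(NNC(=O)c1ccccc1NS(=O)(=O)c1cnc(O)nc1O)c1ccccc1Cl`, carries the same change relative to compound 3: 2-chlorophenyl in place of 4-methylphenyl on a carbonyl carbon.

Since compound 3 sits at the limit of > 20000 nM in this assay, at which 1 of the 3 values shown sits, only a starting limit is known, so a step of an at least 2.5-fold lower number from compound 3 to compound 4 (0.39 log units; beyond the scatter) is expected rather than measured. Compound 4 is estimated at 8000 nM, between 2500 nM and 20000 nM.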

Compound 4, half-maximal inhibitory concentration: 5290 nM
For compound 4 the middle estimate is 1.5-fold (0.18 log units) above the measured one, and the stated range covers the measured number.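

In this assay, 2-chlorophenyl in place of 4-methylphenyl on a carbonyl carbon also lowers the number on the second core, giving an at least 3.7-fold lower number from compound 3 to compound 4 (0.57 log units; beyond the scatter). Compound 3 gives > 20000 nM, which is a limit of the assay and not a number. The change therefore points the same way on both cores, but this does not show that its size carries over: the same change on two cores in this assay, an 8.4-fold lower number (0.92 log units; beyond the scatter) from compound 1 to compound 2 and an at least 3.7-fold lower number (0.57 log units; beyond the scatter) from compound 3 to compound 4; the limit leaves it open whether they differ

As far as these compounds go, these two pairs change both the atom and its place on the ring at once, so the effect of each remains open. Groups such as 2-methylphenyl or 4-chlorophenyl on the same carbonyl carbon would separate the two, and a 2-aminophenyl would show whether the trend extends beyond these groups.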